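The source may hold more compounds than are shown below. What is called first, only, known or untested is meant among the compounds shown, and "the series" means these compounds.

Going by the values given here, in a functional assay on MCF7 cells (Homo sapiens) for antiproliferative activity, read by MTT assay, with stated times of 24 h and 72 h (a lower number here means a stronger inhibitor, a higher number a weaker inhibitor), compound 1 `COc1cc(N2C(=O)[C@@H](Oc3ccccc3)[C@H]2c2cccc([N+](=O)[O-])c2)cc(OC)c1OC` gives 30000 nM and compound 2 `COc1cc(N2C(=O)[C@@H](Oc3ccccc3)[C@H]2c2cccc(O)c2)cc(OC)c1OC` gives 54000 nM, so compound 2 stands within the scatter of its only neighbour. Compound 3 `COc1cc(N2C(=O)[C@@H](Oc3ccccc3)[C@H]2c2cc(N)c(OC)c(O)c2)cc(OC)c1OC` differs from compound 2 by a group of 10 heavy atoms (7 carbon, 1 nitrogen, 2 oxygen; one six-membered aromatic ring of carbon only) in place of a group of 7 heavy atoms (6 carbon, 1 oxygen; one six-membered aromatic ring of carbon only), on a saturated ring carbon, on a saturated ring carbon. Among the compounds with values here, the only measured step, a 1.8-fold higher number from compound 1 to compound 2 (0.26 log units; within the scatter), exchanges one group on the aromatic ring, so it gives no direct measure of this larger exchange. A move to a lower number, beyond the scatter, is tentatively expected, and the expected step is a 110-fold lower number from compound 2 to compound 3 (2.03 log units; beyond the scatter). For compound 3 the estimated value is 500 nM, with an expected range of 40 nM to 8000 nM.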

Compound 3, half-maximal inhibitory concentration: 8800 nM
The estimate for compound 3 lay 18-fold (1.25 log units) below the measured number; the measured number lies above the stated range.
By their numbers in this assay, from the lowest: compound 3; then compounds 1 and 2 (each within the scatter of the next).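

In this assay, the group of 10 heavy atoms on the saturated ring carbon gives a 6.1-fold lower number from compound 2 to compound 3 (0.79 log units; beyond the scatter) and also a 3.4-fold lower number from compound 1 to compound 3 (0.53 log units; beyond the scatter). Going by these compounds alone, this is the first change at this position that lies beyond the scatter, though both steps are modest. No measurement shown here explains the difference.

Compound 3 changes more than one feature of the aromatic ring at once, so the compounds shown do not separate their contributions. They also leave open how a carboxylic acid or an ethoxy group on that ring would compare.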